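The compounds below may be only part of what the source reports. "The series", "measured", "known", "first", "only" and "open" are said of these compounds alone.

In an assay on cell membranes for displacement of a labelled ligand from corticotropin-releasing factor receptor 1 (Rattus norvegicus) (on this read-out lower numbers stand for stronger inhibition and higher numbers for weaker inhibition), compound 1 `CCC(CC)Nc1nc(C)nc2c(-c3cc(F)c(OC)cc3Cl)c(C)nn12` gives 1 nM, compound 3 `CCCN(C)c1nc(C)nc2c(-c3c(C)cc(OC)cc3OC)c(C)nn12` gives 6.48 nM, and compound 2 `CCOCC(COCC)Nc1nc(C)nc2c(-c3ccc(OC)cc3C)c(C)nn12` gives 19.3 nM, the highest of the three numbers; its nearest neighbour is compound 3 and its furthest is compound 1, both gaps lying beyond the scatter. Compound 4 `COc1ccc(-c2c(C)nn3c(N4CCCC4)nc(C)nc23)c(C)c1` differs from compound 2 by pyrrolidin-1-yl in place of (2-ethoxy-1-(ethoxymethyl)ethyl)amino on an aromatic carbon. For the measured compounds named here, no measured pair shows this exact change, but compound 3, which also carries a tertiary amine, gives 6.48 nM in this assay, so a step toward a lower number, beyond the scatter, is expected here. The expected step from compound 2 to compound 4 is a 3.2-fold lower number from compound 2 to compound 4 (0.51 log units; beyond the scatter). Compound 4 is therefore estimated at 6 nM, with a range from 2 nM to 20 nM.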

Compound 4, half-maximal inhibitory concentration: 80.7 nM
Beside the measured number, compound 4's estimate is 13-fold (1.13 log units) below it; the measured number lies above the stated range.
By their numbers in this assay, from the lowest: compound 1; then compound 3; then compound 2; then compound 4.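

In this assay, placing pyrrolidin-1-yl in place of (2-ethoxy-1-(ethoxymethyl)ethyl)amino, on the aromatic carbon between two ring nitrogen atoms, gives a 4.2-fold higher number from compound 2 to compound 4 (0.62 log units; beyond the scatter), a modest step beyond the scatter. For the compounds shown here, this is the first pair that reads this position alone, and it shows that the smaller ring, with no hydrogen-bond donor, gives the weaker inhibition here. No evidence is available to explain this step. The compounds shown leave open how a piperidine or morpholine ring at this position would read on the same core.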